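The source may hold more compounds than are shown below. What is called first, only, known or untested is meant among the compounds shown, and "the series" means these compounds.

Working notes on the series. All three compounds share one core and differ only in the methoxy substitution of one aromatic ring. Among the compounds with values here, compound 1 `COc1ccc(-c2cc(/C=C/C(=O)c3ccc(N)cc3)[nH]n2)cc1` and compound 2 `COc1cc(-c2cc(/C=C/C(=O)c3ccc(N)cc3)[nH]n2)cc(OC)c1OC` are the two measured so far. In a functional assay on NCI/ADR-RES cells (Homo sapiens) for cytotoxicity, read by sulforhodamine B assay, with a stated time of 48 h, tested at 0.01 uM (a lower number here means a stronger effect, a higher number a weaker effect of the compound at the concentration tested), compound 1 gives 101% and compound 2 gives 106%. The two numbers lie within the scatter of one another, so compound 2 is not set apart from compound 1 by this assay at this concentration; both values sit at about the level of untreated cells. Compound 3 `COc1ccc(-c2cc(/C=C/C(=O)c3ccc(N)cc3)[nH]n2)cc1OC` has not yet been measured in this assay. Its change from compound 2 is hydrogen in place of methoxy on an aromatic carbon. Within the data shown here, no step between measured compounds is available, and the two measured values cannot be told apart, so no step beyond the scatter is expected in this assay from this change, in either direction. Compound 3 is expected to give 102% in this assay, within 90% to 114%. The estimated step of a number 4 percentage points lower from compound 2 to compound 3 (within the scatter) is expected to lie within the scatter.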

Compound 3, a percentage reported as activity, at one concentration (the size of the read-out at that concentration, not a potency): 102%
Compound 3: the middle estimate sits on the measured number at the digits printed; the measured number falls inside the stated range.
By their numbers in this assay, from the lowest: compounds 1, 3 and 2 (each within the scatter of the next).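

Hydrogen in place of methoxy on this aromatic carbon, ortho to a methoxy group and meta to a large group, gives a number 4 percentage points lower from compound 2 to compound 3 (within the scatter) in this assay at the one concentration tested. Methoxy in place of hydrogen on an aromatic carbon gives a number 1 percentage points higher from compound 1 to compound 3 (within the scatter) in the same test, so both single changes can now be read as steps, and neither stands beyond the scatter. No measurement is at hand that would explain this result.

Going by these compounds, whether another group at this position, such as a hydroxyl, an amine or a carboxylic acid, would give a step beyond the scatter stays open. The compounds shown also leave open whether the methoxy pattern matters at concentrations higher than the one used here, since a single concentration gives no potency.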